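The source may report more compounds than this note shows. Statements on the series, on what has been measured and on what is new or still open speak of the compounds shown alone.

Among the measured compounds shown here, in a functional assay on HL-60 cells (Homo sapiens) for inhibition, read by MTT assay, with a stated time of 72 h (a higher number here means a weaker inhibitor, a lower number a stronger inhibitor), compound 1 `C=C(C)c1ccc(N2CCN(C(=O)c3oc(C)nc3-c3ccccc3)CC2)cc1` is reported as "not active" (no number reported), while compound 2 `Cc1nc(-c2ccccc2)c(C(=O)N2CCN(c3ccccc3C(F)(F)F)CC2)o1` gives 120 nM, the only actual number so far. Compound 3 `Cc1nc(-c2ccccc2)c(C(=O)N2CCN(c3cc(Cl)cc(Cl)c3)CC2)o1` keeps the core of compound 2 and changes one group: 3,5-dichlorophenyl in place of 2-(trifluoromethyl)phenyl on an amine nitrogen in a ring. For the measured compounds named here, no measured step shows what such a swap does, so the expectation stays cautious. The expected change, a 1.5-fold higher number from compound 2 to compound 3 (0.18 log units; within the scatter), is none beyond the usual scatter. For compound 3 the estimated value is 180 nM, with an expected range of 40 nM to 800 nM.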

Compound 3, half-maximal inhibitory concentration: 41.8 nM
Compound 3: middle estimate off by 4.3-fold (0.63 log units), on the high side; measured number inside the range.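

In this assay, among the compounds shown here, the group on the ring amine nitrogen is the first place where a measured change can be read: 3,5-dichlorophenyl in place of 2-(trifluoromethyl)phenyl gives a 2.9-fold lower number from compound 2 to compound 3 (0.46 log units; beyond the scatter), a modest gain in potency. So this position accepts a different substituted phenyl ring without a loss of activity. Nothing available explains the change.

The two compounds leave open whether the chlorines themselves or where they sit on the ring matter more. As far as these compounds go, how a phenyl ring carrying one chlorine, a methoxy group or an amine would behave here also remains open.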